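The source may hold more compounds than are shown below. What is called first, only, known or untested is meant among the compounds shown, and "the series" means these compounds.

Compound 1 `CCCCCCCCCCCCCCCC[Se]CCC(=O)NCc1ccc(O)c(OC)c1` and compound 2 `CCCCCCCCCCCCCCCC[Se]C[C@H](N)C(=O)NCc1ccc(O)c(OC)c1` share a core in which the chain is joined through selenium; in an assay on HEK293 cells for antagonist activity at transient receptor potential cation channel subfamily V member 2 (Rattus norvegicus), read by fluorescence and calcium flux, with a stated time of 5 min (a lower number here means a stronger inhibitor, a higher number a weaker inhibitor), compound 1 gives 4300 nM and compound 2 gives 1200 nM. The change between them is amino in place of hydrogen on a saturated chain carbon bound to a carbonyl carbon and a saturated chain carbon and it produced a 3.6-fold lower number from compound 1 to compound 2 (0.55 log units; beyond the scatter). Compound 3 `CCCCCCCCCCCCCCCCSCCC(=O)NCc1ccc(O)c(OC)c1` carries sulfur in the corresponding position, and the difference between its core and that of compound 1 is not broken down here; in this assay compound 3 gives 3800 nM, a value within the scatter of compound 1. Compound 4 `CCCCCCCCCCCCCCCCSC[C@H](N)C(=O)NCc1ccc(O)c(OC)c1` differs from compound 3 by amino in place of hydrogen on a saturated chain carbon bound to a carbonyl carbon and a saturated chain carbon, the same change seen from compound 1 to compound 2. Since compound 3 stands close to compound 1 in this assay, the step is expected to be about as large, a 3.5-fold lower number from compound 3 to compound 4 (0.54 log units; beyond the scatter). Compound 4 is therefore estimated at 1100 nM, most likely between 500 nM and 2500 nM.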

Compound 4, half-maximal inhibitory concentration: 1400 nM
For compound 4 the middle estimate is 1.3-fold (0.10 log units) below the measured one; the range from low to high includes it.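

In this assay, amino in place of hydrogen on a saturated chain carbon bound to a carbonyl carbon and a saturated chain carbon again lowers the number on the sulfur-joined core, with a 2.7-fold lower number from compound 3 to compound 4 (0.43 log units; beyond the scatter). Set beside the selenium-joined pair, the two steps cannot be told apart: the same change on two cores in this assay, a 3.6-fold lower number (0.55 log units; beyond the scatter) from compound 1 to compound 2 and a 2.7-fold lower number (0.43 log units; beyond the scatter) from compound 3 to compound 4, 1.3-fold (0.12 log units) apart, within the scatter of two such steps This shows that the change carried over between these two cores at a similar size, but it rests on two pairs only and does not show that it would carry to any other core or explain why the number falls.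

The compounds shown leave open whether a carboxylic acid or a hydroxyl group would do the same at this place. They also leave open how a shorter chain, or a chain joined through oxygen, would behave.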